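A few compounds are considered here, and "the series" means these few. Any claim that something is new, unique, unknown or untested is made for them only; others in the source may bear on it.

Compound 1 `COc1ccn2c(Nc3ccccc3F)c(-c3ccccn3)nc2c1`: 5750 nM
Compound 2 `COc1ccn2c(Nc3ccc(F)cn3)c(-c3ccccn3)nc2c1`: 16000 nM
Compound 3 `N#Cc1ccn2c(Nc3ccc(F)cc3)c(-c3ccccn3)nc2c1`: > 50000 nM

Among the measured compounds shown here, in an ADME assay on THP-1 cells (Homo sapiens) for cytotoxicity (a lower number here means that less compound is tolerated, a higher number that more compound is tolerated), compound 1 gives 5750 nM and compound 2 gives 16000 nM; the only step measured between two compounds, a 2.8-fold higher number from compound 1 to compound 2 (0.44 log units; beyond the scatter), changes the aryl on the amine nitrogen and not the substituent that is at issue here. For compound 3 the result is a limit and not a number, > 50000 nM; (the limit of > 50000 nM in this assay, at which 1 of the 3 values shown sits), so compound 3 is the one whose tolerance could not be pinned down within the range tested.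

Compound 4 `COc1ccn2c(Nc3ccc(F)cc3)c(-c3ccccn3)nc2c1` has not yet been measured. It differs from compound 3 in one place: methoxy in place of cyano on an aromatic carbon. For the measured compounds named here, no measured step follows this exchange, so the expectation rests on the compounds that already carry a methoxy there, compound 1 with 5750 nM and compound 2 with 16000 nM, both of which gave numbers rather than limits. Compound 4 is therefore expected to come out in this assay near those two, at about 10000 nM, plausibly between 4000 nM and 40000 nM. Against the limit of compound 3 this expected result amounts to an at least 5.0-fold lower number from compound 3 to compound 4 (0.69 log units; beyond the scatter), though that step is counted from a limit and is uncertain.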

Compound 4, half-maximal cytotoxic concentration: 4560 nM
The estimate for compound 4 lay 2.2-fold (0.34 log units) above the measured number, and the stated range covers the measured number.
By their numbers in this assay, from the lowest: compounds 4 and 1 (each within the scatter of the next); then compound 2. At a limit, above all of these: compound 3.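

Methoxy in place of cyano on the aromatic carbon opposite the ring nitrogen gives, in this assay, an at least 10-fold lower number from compound 3 to compound 4 (1.04 log units; beyond the scatter), the first step shown that changes this position. Compound 3 stands at a limit, so this step fixes only a bound on the size of the change and not the size itself: the limit of > 50000 nM in this assay, at which 1 of the 4 values shown sits.

With the methoxy kept, the aryl on the amine nitrogen matters less in the steps shown: a 3.5-fold lower number from compound 2 to compound 4 (0.55 log units; beyond the scatter), while a 1.3-fold lower number from compound 1 to compound 4 (0.10 log units; within the scatter).

On these data alone, how far the true value of compound 3 lies beyond its limit remains open. So does whether an amine, a carboxylic acid or a longer alkoxy chain on this carbon would track with the methoxy or with the cyano compound, and whether the change holds with other aryl groups on the nitrogen.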